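Removing the Nitro Group from Compound 2

The source may report more compounds than this note shows. Statements on the series, on what has been measured and on what is new or still open speak of the compounds shown alone.

Among the measured compounds shown here, compound 2 `CCC(C)C(C(=O)Nc1ccc(C(C)=O)cc1)N(C(=O)c1ccccc1)S(=O)(=O)c1ccc([N+](=O)[O-])cc1` stands at the top of the two numbers available so far. In a functional assay for inhibition, read by spectrophotometry, with a stated time of 20 min, tested at 3 mg/mL (on this read-out lower numbers stand for a weaker effect and higher numbers for a stronger effect at the one concentration tested), compound 2 gives 42.1%. For the measured compounds named here, its only neighbour is compound 1 `CC(=O)c1ccc(NC(=O)CN(C(=O)c2ccccc2)S(=O)(=O)c2ccc([N+](=O)[O-])cc2)cc1`, which in this assay gives 20.6%; the one measured step between them is a number 21.5 percentage points higher from compound 1 to compound 2 (beyond the scatter). Compound 3 `CCC(C)C(C(=O)Nc1ccc(C(C)=O)cc1)N(C(=O)c1ccccc1)S(=O)(=O)c1ccccc1` has not been measured and differs from compound 2 in a single place: hydrogen in place of nitro on an aromatic carbon. Cut one bond further out, the change reads (4-nitrophenyl)sulfonyl to phenylsulfonyl. Going by the values given here, the only measured step, sec-butyl in place of hydrogen on a saturated chain carbon bound to an amide-type nitrogen and a carbonyl carbon, concerns a different part of the shared core and so gives no direct guide to removal of the nitro group; no measured pair touches the six-membered aromatic ring of carbon only that carries it. In the absence of any such step, the expected change in this assay from compound 2 to compound 3 is a number 4.1 percentage points lower from compound 2 to compound 3 (within the scatter), nothing beyond the scatter in either direction. Compound 3 is therefore estimated in this assay at 38%, with a range from 15% to 60%.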

Compound 3, a percentage reported as inhibition, at one concentration (the size of the read-out at that concentration, not a potency): 14.3%
For compound 3 the middle estimate is 23.7 percentage points above the measured one; the whole stated range lies above it.
By their numbers in this assay, from the lowest: compounds 3 and 1 (each within the scatter of the next); then compound 2.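

Removing the nitro group is not a neutral change in this assay: putting hydrogen on that aromatic carbon gives a number 27.8 percentage points lower from compound 2 to compound 3 (beyond the scatter). The read-out at the one concentration tested therefore responds to the group on this six-membered aromatic ring of carbon only, a part of the molecule the earlier step did not touch. That earlier step, a number 21.5 percentage points higher from compound 1 to compound 2 (beyond the scatter), concerned the saturated chain carbon, so two separate places on the shared core now each carry a change beyond the scatter, though nothing shown bears on why the read-out falls when the nitro group leaves.

Going by these compounds, it remains open whether the nitro group itself is needed at this aromatic carbon or whether another group there, such as a nitrile, a trifluoromethyl group, an amine or a carboxylic acid, would give a number like that of compound 2. On these data alone, it is equally open whether the loss of the nitro group would count for as much on the core of compound 1, which lacks the sec-butyl group.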